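Taking the Nitro Group off Compound 3

The source may hold more compounds than are shown below. What is called first, only, known or untested is meant among the compounds shown, and "the series" means these compounds.

In a functional assay on MIA PaCa-2 cells (Homo sapiens) for cytotoxicity, read by MTT assay, with a stated time of 72 h (on this read-out higher numbers stand for weaker inhibition and lower numbers for stronger inhibition), compound 1 `COC1=CC(=O)c2c(c(COc3c(F)cc(F)cc3F)c(C)n2C)C1=O` gives 86 nM, compound 2 `COC1=CC(=O)c2c(c(COc3ccncc3)c(C)n2C)C1=O` gives 2170 nM and compound 3 `COC1=CC(=O)c2c(COc3ccc([N+](=O)[O-])cc3)c(C)n(C)c2C1=O` gives 355 nM. Compound 3 therefore stands in the middle, with clearly weaker inhibition than compound 1 and clearly stronger inhibition than compound 2. Compound 4 `COC1=CC(=O)c2c(COc3ccccc3)c(C)n(C)c2C1=O` has hydrogen in place of nitro on an aromatic carbon, para to a large group (hydrogen in place of nitro on an aromatic carbon). For the measured compounds named here, no measured pair shows this change alone, so any forecast is loose. A modest shift towards weaker inhibition is expected in this assay, with an estimated step of a 1.8-fold higher number from compound 3 to compound 4 (0.26 log units; within the scatter) that stays close to the usual scatter. For compound 4, the expected value is 650 nM, with an estimated range of 200 nM to 2100 nM.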

Compound 4, half-maximal inhibitory concentration: 409 nM
Compound 4: middle estimate off by 1.6-fold (0.20 log units), on the high side, and the stated range covers the measured number.
By their numbers in this assay, from the lowest: compound 1; then compounds 3 and 4 (each within the scatter of the next); then compound 2.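

Replacing nitro with hydrogen on this aromatic carbon, para to a large group, gives a 1.2-fold higher number from compound 3 to compound 4 (0.06 log units; within the scatter) in this assay and so leaves the number unchanged within the usual scatter. At this place, then, the nitro group is not needed to keep the activity of compound 3. Nothing measured here explains why this change is tolerated.

From the compounds shown here alone, it remains open whether an amine or a carboxylic acid at the same place would also leave the number unchanged. Whether any group there can shift it beyond the scatter is also unknown.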